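From a Heptyl Chain to an Acetyl Group on Rice

The source may report more compounds than this note shows. Statements on the series, on what has been measured and on what is new or still open speak of the compounds shown alone.

compound 1 `CCCCCc1ccc(NC(=O)N[C@@H](C)c2ccccc2)cc1`: 93%
compound 2 `CCCCCCCc1ccc(NC(=O)N[C@@H](C)c2ccccc2)cc1`: 99%

In an ADME assay on the whole organism with Oryza sativa as the target, tested at 10 uM (a higher number here means a weaker effect of the compound at the concentration tested, a lower number a stronger effect), compound 1 gives 93% and compound 2 gives 99%. Compound 2 stands highest of the two numbers, compound 1 nearest: a number 6 percentage points higher from compound 1 to compound 2 (within the scatter), the change being ethyl in place of hydrogen on a saturated chain carbon, five bonds along the chain from an aromatic carbon. Compound 3 `CC(=O)c1ccc(NC(=O)N[C@@H](C)c2ccccc2)cc1` is the next step: acetyl in place of heptyl on an aromatic carbon. For the measured compounds named here, no measured step alters the group on this aromatic carbon, so nothing measured bears directly on it. The effect in this assay is expected to stay about the same, a number 9 percentage points lower from compound 2 to compound 3 (within the scatter). Compound 3 is estimated at 90% (range 70% to 100%).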

Compound 3, a percentage reported as activity, at one concentration (the size of the read-out at that concentration, not a potency): 96%
Beside the measured number, compound 3's estimate is 6 percentage points below it; the measured number falls inside the stated range.
By their numbers in this assay, from the lowest: compounds 1, 3 and 2 (each within the scatter of the next).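

In this assay the group on this aromatic carbon now changes kind, from a saturated chain to acetyl, which brings a hydrogen-bond acceptor and a double bond. The number still stays within the scatter when acetyl replaces heptyl (a number 3 percentage points lower from compound 2 to compound 3 (within the scatter)) and when it replaces pentyl (a number 3 percentage points higher from compound 1 to compound 3 (within the scatter)). So these three groups cannot be told apart here, and nothing at hand explains this result. Still open, on these data alone, is whether an amine or a carboxylic acid on this carbon would give a clearly lower number in this assay.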